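This account rests on a few compounds, and the source may have more. Where it says the series, first, only, none or still open, it means among the compounds named here.

In a functional assay on MCF7 cells (Homo sapiens) for antiproliferative activity, read by MTT assay, with a stated time of 48 h (a higher number here means a weaker inhibitor, a lower number a stronger inhibitor), compound 1 `COC(=O)[C@H](C)NC(=O)c1ccc(Oc2nc3ccccc3nc2C)cc1` gives 38400 nM, compound 2 `CC[C@@H](C)[C@H](NC(=O)c1ccc(Oc2nc3ccccc3nc2C)cc1)C(=O)OC` gives 36100 nM and compound 3 `Cc1nc2ccccc2nc1Oc1ccc(C(=O)N[C@@H](C)C(=O)O)cc1` gives 25600 nM, so compound 3 stands level with both others within the scatter. Compound 4 `CC[C@@H](C)[C@H](NC(=O)c1ccc(Oc2nc3ccccc3nc2C)cc1)C(=O)O` differs from compound 3 by one change, sec-butyl in place of methyl on a saturated chain carbon bound to an amide-type nitrogen and a carbonyl carbon. The two other measured steps, a 1.5-fold lower number from compound 1 to compound 3 (0.18 log units; within the scatter) and a 1.4-fold lower number from compound 2 to compound 3 (0.15 log units; within the scatter), also stay within the scatter. The same swap, measured once, gave a 1.1-fold lower number from compound 1 to compound 2 (0.03 log units; within the scatter), so no step beyond the scatter is expected in this assay. The estimated step is a 1.1-fold lower number from compound 3 to compound 4 (0.03 log units; within the scatter). For compound 4 the expected value is 24000 nM, with an estimated range of 12000 nM to 48000 nM.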

Compound 4, half-maximal inhibitory concentration: 35700 nM
Beside the measured number, compound 4's estimate is 1.5-fold (0.17 log units) below it; the range from low to high includes it.
By their numbers in this assay, from the lowest: compounds 3, 4, 2 and 1 (each within the scatter of the next).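

On the core of compound 3, sec-butyl in place of methyl in this assay gives a 1.4-fold higher number from compound 3 to compound 4 (0.14 log units; within the scatter), so this change stays within the scatter on a second core: the same change on two cores in this assay, a 1.1-fold lower number (0.03 log units; within the scatter) from compound 1 to compound 2 and a 1.4-fold higher number (0.14 log units; within the scatter) from compound 3 to compound 4, 1.5-fold (0.17 log units) apart, within the scatter of two such steps
Hydrogen in place of methyl on an oxygen next to a carbonyl group, now measured with sec-butyl present, gives a 1.0-fold lower number from compound 2 to compound 4 (0.00 log units; within the scatter), and it also stays within the scatter on both cores: the same change on two cores in this assay, a 1.5-fold lower number (0.18 log units; within the scatter) from compound 1 to compound 3 and a 1.0-fold lower number (0.00 log units; within the scatter) from compound 2 to compound 4, 1.5-fold (0.17 log units) apart, within the scatter of two such steps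
Changing both places together gives a 1.1-fold lower number from compound 1 to compound 4 (0.03 log units; within the scatter), so the two changes combined also produce no step beyond the scatter.
Going by these compounds, whether a benzyl group or a longer chain ending in an amine on this saturated chain carbon would give a step beyond the scatter remains open.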